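The source may report more compounds than this note shows. Statements on the series, on what has been measured and on what is new or still open speak of the compounds shown alone.

Compound 1 `CNC(=O)c1cc(C(=O)N[C@H]2CC[C@H](O)CC2)cc2c1OC[C@@]2(C)c1ccccc1` carries a 4-hydroxycyclohexyl group on an amide-type nitrogen. In a physicochemical assay for solubility (a lower number here means a less soluble compound, a higher number a more soluble compound), compound 1 gives >= 161 ug/mL, and this reading is a limit of the assay, not a number. A second compound, compound 2 `CNC(=O)c1cc(C(=O)NCCC[C@H]2OC[C@H](N)CO2)cc2c1OC[C@H]2c1ccccc1`, gives >= 153 ug/mL, which is also a limit. With only these two limits in hand, the two compounds cannot be put in order.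

Compound 3 `CNC(=O)c1cc(C(=O)N[C@H]2[C@@H]3C[C@@H](O)C[C@@H]32)cc2c1OC[C@@]2(C)c1ccccc1` keeps the core of compound 1 and changes one group, as follows: a group of 7 heavy atoms (6 carbon, 1 oxygen; one three-membered non-aromatic ring of carbon only, one five-membered non-aromatic ring of carbon only) in place of a group of 7 heavy atoms (6 carbon, 1 oxygen; one six-membered non-aromatic ring of carbon only), on an amide-type nitrogen. For the measured compounds named here, no measured pair of compounds differs in one place, so the expectation rests on the structural change alone. The two groups have the same heavy atoms, hydrogen-bond donors and hydrogen-bond acceptors, but different rings. The expected step of an at least 1.0-fold lower number from compound 1 to compound 3 (0.03 log units; that floor lies within the scatter) is none beyond the usual scatter. For compound 3 the estimated value in this assay is 150 ug/mL, with an expected range from 70 ug/mL to 200 ug/mL.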

Compound 3, solubility: >= 209 ug/mL
Compound 3: only a limit was reported (the forecaster's own chance of this, stated with the estimate: 60%); at least 1.3-fold (0.14 log units) between middle value and limit.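

In this assay compound 3 gives >= 209 ug/mL, which is a limit of the assay. Compound 1 gives >= 161 ug/mL, also a limit. These two limits leave the step between compound 1 and compound 3 unreadable. Which of these two compounds would give the higher number in this assay stays open.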